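Swapping oxolan-3-yl for oxan-4-yl on the aromatic nitrogen

The source may hold more compounds than are shown below. What is called first, only, known or untested is meant among the compounds shown, and "the series" means these compounds.

Going by the values given here, in a functional assay on HT-29 cells (Homo sapiens) for inhibition, read by luminescence and CellTiter-Glo, with a stated time of 24 h (on this read-out higher numbers stand for an effect only at larger amounts of compound and lower numbers for an effect already at smaller amounts), compound 2 (`CN1C(=S)[C@@H](NC(=O)c2nc(Cc3ccccc3)n(C3CCOC3)n2)COc2ccccc21`) gives 1580 nM, the higher of the two numbers so far, while compound 1 (`COCCn1nc(C(=O)N[C@H]2COc3ccccc3N(C)C2=S)nc1Cc1ccccc1`) gives 566 nM. Compound 3 (`CN1C(=S)[C@@H](NC(=O)c2nc(Cc3ccccc3)n(C3CCOCC3)n2)COc2ccccc21`) carries oxan-4-yl in place of oxolan-3-yl on an aromatic nitrogen. Among the compounds with values here, the only measured step at this place, a 2.8-fold higher number from compound 1 to compound 2 (0.45 log units; beyond the scatter), is modest and belongs to a different swap, from 2-methoxyethyl to oxolan-3-yl, so it gives no clear direction here. The expected step, a 1.2-fold lower number from compound 2 to compound 3 (0.08 log units; within the scatter), therefore stays within the scatter. For compound 3 the estimated value is 1300 nM, with an expected range from 450 nM to 3500 nM.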

Compound 3, half-maximal effective concentration: 2260 nM
Compound 3: the middle estimate sits 1.7-fold (0.24 log units) below what was measured, within the range that was stated.
By their numbers in this assay, from the lowest: compound 1; then compounds 2 and 3 (each within the scatter of the next).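

In this assay, going from the five-membered oxolan-3-yl to the six-membered oxan-4-yl gives a 1.4-fold higher number from compound 2 to compound 3 (0.16 log units; within the scatter) and so no difference that can be told apart, which means ring size matters little at this position. Replacing the open-chain 2-methoxyethyl with oxan-4-yl gives a 4.0-fold higher number from compound 1 to compound 3 (0.60 log units; beyond the scatter) as a modest step, so both rings here go with higher numbers than that chain. Nothing measured on hand explains this. As far as these compounds go, whether a longer ether chain would bring lower numbers than 2-methoxyethyl stays open. So does the outcome for a ring carrying an amine, such as piperidin-4-yl.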